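This account rests on a few compounds, and the source may have more. Where it says the series, first, only, none or still open, it means among the compounds named here.

Measured in an ADME assay on MDCKII-LE cells (Canis lupus familiaris) for permeability; a lower number here means that the compound crosses the layer more slowly, a higher number that the compound crosses the layer faster:

- Compound 1 `Cc1cnc(NC(=O)c2cc(Oc3cnc(C(=O)N(C)C)cn3)c3cc(C)oc3c2)cn1`: 22.3 10^-6 cm/s
- Compound 2 `Cc1cnc(NC(=O)c2cc(Oc3cnc(C(=O)N(C)C)cn3)c3cc(C)nn3c2)cn1`: 17 10^-6 cm/s
- Compound 3 `Cc1cnc(NC(=O)c2cc(Oc3ccc(S(C)(=O)=O)cc3)c3cn(C)nc3c2)cn1`: 20.4 10^-6 cm/s

These three values lie within the usual scatter of one another, so compound 3 stands level with the other two. Compound 4 `Cc1cnc(NC(=O)c2cc(Oc3ccc(S(=O)(=O)C4CC4)cc3)c3cn(C)nc3c2)cn1` matches compound 3 except for one group: it has cyclopropyl in place of methyl on a sulfonyl sulfur, (cyclopropyl in place of methyl on a sulfonyl sulfur). Among the measured compounds shown here, no measured pair shows this change, so the data give no direct guide to its size or direction. The expectation therefore starts from compound 3 at 20.4 10^-6 cm/s and allows no shift beyond the scatter in this assay. The expected step is a 1.1-fold higher number from compound 3 to compound 4 (0.03 log units; within the scatter), which stays within the scatter. For compound 4 the estimate is 22 10^-6 cm/s, with an expected range from 13 10^-6 cm/s to 35 10^-6 cm/s.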

Compound 4, apparent permeability: 17.8 10^-6 cm/s
Beside the measured number, compound 4's estimate is 1.2-fold (0.09 log units) above it, within the range that was stated.
By their numbers in this assay, from the lowest: compounds 2, 4, 3 and 1 (each within the scatter of the next).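

Among the compounds shown here, putting cyclopropyl in place of methyl on a sulfonyl sulfur gives a 1.1-fold lower number from compound 3 to compound 4 (0.06 log units; within the scatter) in this assay and offers the first comparison here of compounds that differ in one place. In this single pair, the exchange of methylsulfonyl for cyclopropylsulfonyl leaves the two compounds level. No available evidence bears on this result.

As far as these compounds go, whether an amine, a carboxylic acid or a longer chain on the sulfonyl sulfur would also stay level remains open. So does whether the same exchange would behave alike on a different core.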